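Thiophene for ethylphenyl on a bromoacrylamide-bearing core

The source may hold more compounds than are shown below. What is called first, only, known or untested is meant among the compounds shown, and "the series" means these compounds.

Compound 2 `C=C(Br)C(=O)Nc1cccc(-c2cn3nc(-c4ccc(CC)cc4)sc3n2)c1` gives 2200 nM in a functional assay on L1210 cells (Mus musculus) for inhibition, read by cell counting, with a stated time of 2 days (on this read-out lower numbers stand for stronger inhibition and higher numbers for weaker inhibition), the second highest of three numbers. Its nearest neighbour is compound 3 `C=C(Br)C(=O)Nc1cccc(-c2cn3c(-c4ccc(Cl)cc4)csc3n2)c1`, which gives 1900 nM, within the scatter of compound 2. Among the compounds with values here, compound 1 `CCc1ccc(-c2nn3cc(-c4cccc(N)c4)nc3s2)cc1`, which lacks the acrylamide, gives 6000 nM; the only single-point step among the measured compounds is a 2.7-fold lower number from compound 1 to compound 2 (0.44 log units; beyond the scatter). Compound 4 `C=C(Br)C(=O)Nc1cccc(-c2cn3nc(-c4cccs4)sc3n2)c1` is not yet measured; it differs from compound 2 in one place: thiophen-2-yl in place of 4-ethylphenyl on an aromatic carbon. Within the data shown here, no measured step concerns this aryl exchange, and compound 3 differs from compound 2 in more than one place, so the data give no direct guide. A step of a 1.1-fold higher number from compound 2 to compound 4 (0.06 log units; within the scatter) is expected, not beyond the scatter. Compound 4 is therefore estimated at 2500 nM, between 900 nM and 7000 nM.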

Compound 4, half-maximal inhibitory concentration: 170 nM
Compound 4: middle estimate off by 15-fold (1.17 log units), on the high side, and the stated range ends above it.
By their numbers in this assay, from the lowest: compound 4; then compounds 3 and 2 (each within the scatter of the next); then compound 1.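

Within the data shown here, putting thiophen-2-yl in place of 4-ethylphenyl on this aromatic carbon gives a 13-fold lower number from compound 2 to compound 4 (1.11 log units; beyond the scatter) in this assay, so the group at this position can change the number strongly, which the earlier compounds could not show. This large step exceeds the modest one from adding the (1-bromoethenyl)carbonyl group, a 2.7-fold lower number from compound 1 to compound 2 (0.44 log units; beyond the scatter). Nothing measured here bears on why the number falls. From the compounds shown here alone, whether unsubstituted phenyl or furan-2-yl on this carbon would give a similar number remains open. So does whether thiophen-2-yl would have the same effect with an unsubstituted amine in place of the bromoacrylamide.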